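From pyridin-4-yl to pyridin-2-yl: compound 1 to compound 3

The source may report more compounds than this note shows. Statements on the series, on what has been measured and on what is new or still open speak of the compounds shown alone.

Compound 1 `O=C(NS(=O)(=O)c1ccc(F)cc1)c1ccncc1` gives 13800 nM in a functional assay on B16-F10 cells (Mus musculus) for antiproliferative activity, read by colorimetric assay and MTT assay, with a stated time of 48 h; on this read-out higher numbers stand for weaker inhibition and lower numbers for stronger inhibition
Compound 2 `Cc1ccc(S(=O)(=O)NC(=O)c2ccncc2)cc1` gives 16200 nM in this assay

Compound 1 and compound 2 lie within the scatter of each other, so compound 1 has no clear standing in this pair. Compound 3 `O=C(NS(=O)(=O)c1ccc(F)cc1)c1ccccn1` differs from compound 1 by pyridin-2-yl in place of pyridin-4-yl on a carbonyl carbon with pyridin-2-yl in place of pyridin-4-yl on a carbonyl carbon. Among the measured compounds shown here, the only measured step, a 1.2-fold higher number from compound 1 to compound 2 (0.07 log units; within the scatter), lies at another place, so no measured step covers this change. In this assay the estimated step is a 1.2-fold lower number from compound 1 to compound 3 (0.06 log units; within the scatter) and no shift beyond the scatter is expected. For compound 3 the expected value is 12000 nM (estimated range 4000 nM to 35000 nM) on present evidence.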

Compound 3, half-maximal inhibitory concentration: 10900 nM
For compound 3 the middle estimate is 1.1-fold (0.04 log units) above the measured one; the measured number falls inside the stated range.
By their numbers in this assay, from the lowest: compounds 3, 1 and 2 (each within the scatter of the next).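

In this assay the change from pyridin-4-yl to pyridin-2-yl on the carbonyl carbon, the first change read at this place, gives a 1.3-fold lower number from compound 1 to compound 3 (0.10 log units; within the scatter) and leaves the read-out within the scatter. This place, like the aromatic carbon bearing fluoro or methyl, has so far shown no step beyond the scatter. Nothing measured here bears on why this is so.

On these data alone, it remains open whether pyridin-3-yl or a plain phenyl would behave the same at this place. As far as these compounds go, it is also open whether an amine or a carboxylic acid on the ring would produce a step beyond the scatter.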